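Amine-bearing chains on the ring amide nitrogen of the core

The source may hold more compounds than are shown below. What is called first, only, known or untested is meant among the compounds shown, and "the series" means these compounds.

Measured so far:
compound 1, `CCC(C)N1C(=O)NC2(CSC3=C2C(=O)c2ccccc2C3=O)C1=O`: 178 nM
compound 2, `CN(C)CCCN1C(=O)NC2(CSC3=C2C(=O)c2ccccc2C3=O)C1=O`: 19 nM; 19 nM; 27 nM (3 entries)

Going by the values given here, in a functional assay on MCF7 cells (Homo sapiens) for inhibition (a lower number here means a stronger inhibitor, a higher number a weaker inhibitor), compound 1 gives 178 nM; this is the only number recorded for compound 1 in this assay, with one further entry that carries no single number. Compound 2 sits at a lower value, with repeat entries that agree closely (the several entries of compound 2 in this assay, 19 nM; 19 nM; 27 nM (3 entries)). Compound 3, `CCN(CC)CCN1C(=O)NC2(CSC3=C2C(=O)c2ccccc2C3=O)C1=O`, is not yet measured in this assay. It differs from compound 1 by 2-(diethylamino)ethyl in place of sec-butyl on an amide-type nitrogen in a ring. Among the compounds with values here, no measured step covers this exact exchange; the nearest comparison is compound 2, whose basic chain on the same nitrogen goes with the lower value in this assay. A step beyond the scatter, towards stronger inhibition, is therefore expected from compound 1 to compound 3, of size a 5.9-fold lower number from compound 1 to compound 3 (0.77 log units; beyond the scatter). Compound 3 is estimated at 30 nM, within 10 nM to 100 nM.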

Compound 3, half-maximal inhibitory concentration: 21 nM
The estimate for compound 3 lay 1.4-fold (0.15 log units) above the measured number; measured number inside the range.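

In this assay, replacing sec-butyl with 2-(diethylamino)ethyl on the amide-type nitrogen in a ring gives an 8.5-fold lower number from compound 1 to compound 3 (0.93 log units; beyond the scatter), the first step read directly at this position. The lower number is thus not confined to the chain of compound 2: a second amine-bearing chain, with a different length and different groups on its nitrogen, reaches the same range. Compound 3, at 21 nM, falls inside the span of the repeat entries of compound 2: the several entries of compound 2 in this assay, 19 nM; 19 nM; 27 nM (3 entries)

From the compounds shown here alone, the step changes chain size and adds the amine nitrogen at once, so the share of each remains open, and a plain hexyl chain would separate the two. Also open, going by these compounds, is how the series responds to a cyclic amine such as morpholine or to a carboxylic acid at the chain end.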